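The source may hold more compounds than are shown below. What is called first, only, known or untested is meant among the compounds shown, and "the series" means these compounds.

In a functional assay for inhibition, read by spectrophotometry, with a stated time of 20 min, tested at 5 mg/mL (on this read-out higher numbers stand for a stronger effect at the one concentration tested and lower numbers for a weaker effect), the three measured compounds stand as follows: compound 1 `CC(=O)c1ccc(NC(=O)CN(C(=O)c2ccccc2)S(=O)(=O)c2ccc([N+](=O)[O-])cc2)cc1` gives 20.7%; compound 2 `CC(=O)c1ccc(NC(=O)C(CC(C)C)N(C(=O)c2ccccc2)S(=O)(=O)c2ccc([N+](=O)[O-])cc2)cc1` gives 81.3%; compound 3 `CCC(C)C(C(=O)Nc1ccc(C(C)=O)cc1)N(C(=O)c1ccccc1)S(=O)(=O)c1ccc([N+](=O)[O-])cc1` gives 53.2%.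

Compound 3 is thus second of the three, below compound 2 by a number 28.1 percentage points lower from compound 2 to compound 3 (beyond the scatter) and above compound 1 by a number 32.5 percentage points higher from compound 1 to compound 3 (beyond the scatter). Compound 4 `CC(=O)c1ccc(NC(=O)C(C(C)C)N(C(=O)c2ccccc2)S(=O)(=O)c2ccc([N+](=O)[O-])cc2)cc1` differs from compound 3 by hydrogen in place of methyl on a saturated chain carbon, three bonds along the chain from an amide-type nitrogen and a carbonyl carbon. For the measured compounds named here, the steps that bear on this are the large gains a number 60.6 percentage points higher from compound 1 to compound 2 (beyond the scatter) and a number 32.5 percentage points higher from compound 1 to compound 3 (beyond the scatter), which show that any branch on that chain carbon lifts the read-out far above compound 1, and the modest drop a number 28.1 percentage points lower from compound 2 to compound 3 (beyond the scatter), which shows that the shape of the branch matters less. Compound 4 keeps a branch but loses one carbon, so a small fall or no change beyond the scatter is expected, a number 11.2 percentage points lower from compound 3 to compound 4 (beyond the scatter). For compound 4 the estimate in this assay is 42%, within 22% to 62%.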

Compound 4, a percentage reported as inhibition, at one concentration (the size of the read-out at that concentration, not a potency): 27.4%
For compound 4 the middle estimate is 14.6 percentage points above the measured one; low and high end bracket the measured number.
By their numbers in this assay, from the lowest: compounds 1 and 4 (each within the scatter of the next); then compound 3; then compound 2.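

Any branch at this chain carbon is not enough to lift the read-out, as isopropyl in place of hydrogen gives only a number 6.7 percentage points higher from compound 1 to compound 4 (within the scatter), which corrects the reading from the earlier compounds. The group's identity matters sharply: isopropyl in place of isobutyl gives a number 53.9 percentage points lower from compound 2 to compound 4 (beyond the scatter), and hydrogen in place of methyl, the sec-butyl to isopropyl change, gives a number 25.8 percentage points lower from compound 3 to compound 4 (beyond the scatter). No measurement here accounts for these steps.

Going by these compounds, whether a longer chain at this carbon would match or pass isobutyl remains open, as does the outcome with a chain ending in an amine or a carboxylic acid.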